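This account rests on a few compounds, and the source may have more. Where it says the series, first, only, none or still open, it means among the compounds named here.

Within the data shown here, compound 1 `O=c1oc2ccccc2cc1C1=NN(c2ccccc2)[C@@H](/C=C/c2ccccc2)C1` gives 26.7% in a functional assay on the whole organism (strain albino) for inhibition, with Rattus norvegicus as the target, read by paw edema, with stated times of 1 h and 2 h, at a dose of 200 mg/kg by the oral route (on this read-out lower numbers stand for less inhibition and higher numbers for more inhibition at the one dose given (going by the name of the read-out)), the lowest of the two numbers measured so far, though its only neighbour lies within the scatter. Compound 2 `Cc1ccc([C@H]2CC(c3cc4ccccc4oc3=O)=NN2c2ccccc2)cc1` gives 30.1% in this assay. The measured step is a number 3.4 percentage points higher from compound 1 to compound 2 (within the scatter). Compound 3 `O=c1oc2ccccc2cc1C1=NN(c2ccccc2)[C@@H](c2ccccc2[N+](=O)[O-])C1` differs from compound 1 by 2-nitrophenyl in place of 2-phenylethenyl on a saturated ring carbon. That one step bears on this change, since it also replaced 2-phenylethenyl at the same saturated ring carbon, and it stayed within the scatter. No move beyond the scatter is expected here either. Compound 3 is therefore estimated at 29%, between 18% and 40%. The expected step is a number 2.3 percentage points higher from compound 1 to compound 3 (within the scatter).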

Compound 3, a percentage reported as inhibition, in the whole organism at one dose (the size of the read-out at that dose, not a potency): 24.7%
Compound 3: middle estimate off by 4.3 percentage points, on the high side, within the range that was stated.
By their numbers in this assay, from the lowest: compounds 3, 1 and 2 (each within the scatter of the next).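

At this saturated ring carbon, 2-nitrophenyl now joins 2-phenylethenyl and 4-methylphenyl, and in this assay it gives a number 2 percentage points lower from compound 1 to compound 3 (within the scatter) and a number 5.4 percentage points lower from compound 2 to compound 3 (within the scatter) at this one dose. Even 2-nitrophenyl, which brings hydrogen-bond acceptors that 2-phenylethenyl lacks, leaves the number within the scatter of both other compounds. No measurement here offers an explanation for this flat result.

All three groups hold a six-membered aromatic ring of carbon only. The compounds shown therefore leave open whether an amine, a carboxylic acid or a saturated alkyl chain on this carbon would move the number beyond the scatter.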